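Lipophilicity notes: thiophen-2-yl replacing 4-bromophenyl

A few compounds are considered here, and "the series" means these few. Any claim that something is new, unique, unknown or untested is made for them only; others in the source may bear on it.

Measured so far:
compound 1 `O=Cc1ccc(-c2cn3ccnc3c(-c3ccc4ncn(C5CCCCC5)c4c3)n2)cc1` — 1.5
compound 2 `Brc1ccc(-c2cn3ccnc3c(-c3ccc4ncn(C5CCCCC5)c4c3)n2)cc1` — 1.73

In a physicochemical assay for lipophilicity, using the shake flask method, in phosphate buffer, measured as octanol-water partition, with a stated time of 85 min, at pH 7.4 (on this read-out higher numbers stand for higher lipophilicity and lower numbers for lower lipophilicity), compound 2 stands highest of the two numbers, with compound 1 nearest, a step of a number 0.23 log units higher from compound 1 to compound 2 (within the scatter). Compound 3 `c1csc(-c2cn3ccnc3c(-c3ccc4ncn(C5CCCCC5)c4c3)n2)c1` is not yet measured. Its change from compound 2 is thiophen-2-yl in place of 4-bromophenyl on an aromatic carbon. Within the data shown here, no measured step exchanges the ring itself; the single step, bromo for formyl, stayed within the scatter, so the reference is thin. A thiophen-2-yl in place of 4-bromophenyl is expected to lower lipophilicity, a step of a number 0.53 log units lower from compound 2 to compound 3 (beyond the scatter) in this assay. Compound 3 is estimated at 1.2, range 0.7 to 1.7.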

Compound 3, partition coefficient: 1.38
For compound 3 the middle estimate is 0.18 log units below the measured one, and the stated range covers the measured number.
By their numbers in this assay, from the lowest: compounds 3, 1 and 2 (each within the scatter of the next, the first and the last beyond it).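

In this assay, among these compounds, thiophen-2-yl in place of 4-bromophenyl gives a number 0.35 log units lower from compound 2 to compound 3 (beyond the scatter) and is the first change at this position to clear the scatter. Against 4-formylphenyl, the same ring gives only a number 0.12 log units lower from compound 1 to compound 3 (within the scatter) so the reading depends on which phenyl group serves as the reference. No available data explain either step. Still open, from the compounds shown here alone, is how an amine or a carboxylic acid on the ring at this position would compare with these groups, and whether the thiophene attachment isomer, thiophen-3-yl, would match thiophen-2-yl.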